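The source may report more compounds than this note shows. Statements on the series, on what has been measured and on what is new or still open speak of the compounds shown alone.

Measured so far:
compound 1 `Cn1cccc1-c1cc(-c2ccc(Br)cc2)[nH]c(=O)c1C#N` — > 100000 nM
compound 2 `COc1ccc(-c2cc(-c3cccs3)[nH]c(=O)c2C#N)cc1` — > 100000 nM

Compound 1 `Cn1cccc1-c1cc(-c2ccc(Br)cc2)[nH]c(=O)c1C#N` carries the shared core with a 4-bromophenyl group and a 1-methyl-1H-pyrrol-2-yl group. In a functional assay on T47D cells (Homo sapiens) for cytotoxicity, read by sulforhodamine B assay, with a stated time of 48 h (on this read-out higher numbers stand for weaker inhibition of growth and lower numbers for stronger inhibition of growth), compound 1 gives > 100000 nM, which is a limit of the assay and not a number. Compound 2 `COc1ccc(-c2cc(-c3cccs3)[nH]c(=O)c2C#N)cc1` likewise gives only a limit in this assay, > 100000 nM. Among the measured compounds shown here, both measured values sit at the limit of > 100000 nM in this assay, at which 2 of the 2 values shown sit, so no step between measured compounds is known and compound 1 cannot be placed on a scale; it simply shows no growth inhibition within the measured window.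

Compound 3 `Cn1cccc1-c1cc(-c2ccc(Br)cc2)n(C(=S)Nc2ccc(F)cc2)c(=O)c1C#N` differs from compound 1 by a group of 10 heavy atoms (7 carbon, 1 nitrogen, 1 fluorine, 1 sulfur; one six-membered aromatic ring of carbon only) in place of a hydrogen atom, on an aromatic nitrogen. For the measured compounds named here, no measured step informs the direction of this change. The expected step toward stronger inhibition of growth, with wide uncertainty, is estimated as an at least 2.5-fold lower number from compound 1 to compound 3 (0.39 log units; beyond the scatter). For compound 3 the estimate in this assay is 40000 nM, with a range of 5000 nM to 150000 nM.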

Compound 3, concentration for 50% growth inhibition: > 100000 nM
Compound 3: a limit, no number; the forecaster's own chance of this, stated with the estimate: 50%; middle value at least 2.5-fold (0.39 log units) from the limit.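

No step can be read from compound 1 to compound 3, since both values are limits and not numbers: the limit of > 100000 nM in this assay, at which 3 of the 3 values shown sit. The compounds shown leave open whether the group on the aromatic nitrogen changes growth inhibition at all, and whether any variation on the shared core gives a measurable value.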